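The compounds below may be only part of what the source reports. "The series", "measured", "known", "first", "only" and "open" are said of these compounds alone.

The step from compound 3 to compound 4 is set against three measured compounds, all read in an ADME assay on MDCK cells (Canis lupus familiaris) for cytotoxicity, read by microscopy, with a stated time of 72 h; on this read-out lower numbers stand for higher toxicity in this test and higher numbers for lower toxicity in this test. Compound 1, `COC(=O)C[C@H](NC(=O)OC(C)(C)C)C(=O)N(Cc1ccc(F)cc1)C1(C(=O)NCc2ccccc2)CCN(C)CC1`, gives 17000 nM. Compound 2, `COC(=O)C[C@H](NC(=O)OC(C)(C)C)C(=O)N(Cc1ccc(F)cc1)C1(C(=O)NCS(=O)(=O)c2ccc(C)cc2)CCN(Cc2ccccc2)CC1`, gives 4000 nM. Compound 3, `COC(=O)C[C@H](NC(=O)OC(C)(C)C)C(=O)N(C1CC1)C1(C(=O)NCc2ccccc2)CCN(Cc2ccccc2)CC1`, gives 84000 nM, the highest of the three numbers and beyond the scatter from both others, so it is the least toxic of the three in this assay. Compound 4 is `COC(=O)C[C@H](NC(=O)OC(C)(C)C)C(=O)N(Cc1ccc(Cl)cc1)C1(C(=O)NCc2ccccc2)CCN(Cc2ccccc2)CC1`. It differs from compound 3 in one place: 4-chlorobenzyl in place of cyclopropyl on an amide-type nitrogen. Among the compounds with values here, no pair of measured compounds differs in only one place, so no measured step covers this change. Compound 1 carries a benzyl-type group on that amide nitrogen and shows a lower number than compound 3, but it also differs elsewhere, so it only points the way. The change is expected to lower the number, a 4.2-fold lower number from compound 3 to compound 4 (0.62 log units; beyond the scatter), since the closest comparison is compound 1 at 17000 nM. Compound 4 is therefore estimated at 20000 nM, between 7000 nM and 60000 nM.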

Compound 4, minimum cytotoxic concentration: 100000 nM
Beside the measured number, compound 4's estimate is 5.0-fold (0.70 log units) below it, outside the stated range (above it).
By their numbers in this assay, from the lowest: compound 2; then compound 1; then compounds 3 and 4 (each within the scatter of the next).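

In this assay, putting 4-chlorobenzyl in place of cyclopropyl on this amide-type nitrogen gives a 1.2-fold higher number from compound 3 to compound 4 (0.08 log units; within the scatter), so the two compounds read alike. Within the data shown here, this is the first comparison in the set that isolates a single place. It shows that a group of 8 heavy atoms with a six-membered aromatic ring can replace one of 3 heavy atoms with a three-membered ring without a step beyond the scatter, at least on this core. Nothing available here explains why the two groups read alike.

On these data alone, whether this holds for other kinds of group on the same nitrogen stays open, for example a longer carbon chain, or a chain ending in an amine or a carboxylic acid. As far as these compounds go, it is also open whether the same swap would read alike with a different group elsewhere on the core.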